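Amide nitrogen substituent swap on the shared dihydrofuran core

A few compounds are considered here, and "the series" means these few. Any claim that something is new, unique, unknown or untested is made for them only; others in the source may bear on it.

Compound 1 `C=CC1=C(C(=O)O)C(c2ccc(F)cc2)OC1` reports only a limit, > 100000 nM, in a functional assay on QGY7701 cells (Homo sapiens) for cytotoxicity, read by MTT assay, with a stated time of 24 h (a higher number here means a weaker inhibitor, a lower number a stronger inhibitor), a limit rather than a number (the limit of > 100000 nM in this assay, at which 1 of the 2 values shown sits). Among the measured compounds shown here, compound 2 `C=CC1=C(C(=O)Nc2ccccc2OC)C(c2ccc(F)cc2)OC1` gives 52800 nM in this assay, the only numeric value in this set. Compound 3 `C=CC1=C(C(=O)NCC(C)C)C(c2ccc(F)cc2)OC1` is not yet measured; it carries isobutyl in place of 2-methoxyphenyl on an amide-type nitrogen. For the measured compounds named here, no step between measured compounds is available to calibrate this change, so the step from compound 2 to compound 3 is expected to be modest, within or just beyond the scatter, with weaker inhibition slightly more likely. Compound 3 is therefore estimated at 75000 nM in this assay, between 25000 nM and 200000 nM. The expected step is a 1.4-fold higher number from compound 2 to compound 3 (0.15 log units; within the scatter).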

Compound 3, half-maximal inhibitory concentration: > 100000 nM
Compound 3 was reported as a limit; the forecaster's own chance of this, stated with the estimate: 35%; at least 1.3-fold (0.12 log units) between middle value and limit.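

On the amide-type nitrogen, isobutyl in place of 2-methoxyphenyl gives, in this assay, an at least 1.8-fold higher number from compound 2 to compound 3 (0.27 log units; that floor lies within the scatter), so the change sets only a floor and no measured size. Compound 3 gives > 100000 nM, which is a limit and not a number. The only numeric value in the set therefore remains that of compound 2, and the series has little readable range: the limit of > 100000 nM in this assay, at which 2 of the 3 values shown sit.

The step from compound 1 to compound 3 cannot be read from two limits. As far as these compounds go, whether an unsubstituted phenyl or a longer chain on this nitrogen would give a numeric value stays open.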